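Chloro on the furan of compound 2: expected shift

The source may report more compounds than this note shows. Statements on the series, on what has been measured and on what is new or still open speak of the compounds shown alone.

Among the measured compounds shown here, the two compounds measured so far are compound 1 `N#C/C(=C\c1c(F)c(F)c(F)c(F)c1F)C(=O)c1ccc[nH]1` and compound 2 `COc1ccc(CNC(=O)/C(C#N)=C/c2ccco2)cc1`. In a functional assay on MCF7 cells (Homo sapiens) for inhibition, read by MTT assay, with a stated time of 72 h (a higher number here means a weaker inhibitor of growth, a lower number a stronger inhibitor of growth), compound 1 gives 23000 nM. In this assay compound 2 gives 27000 nM, the higher of the two numbers; its nearest neighbour is compound 1, and the gap between the two lies within the scatter, so no order between them can be read from these figures. The next step is compound 3 `COc1ccc(CNC(=O)/C(C#N)=C/c2ccc(Cl)o2)cc1`, which carries chloro in place of hydrogen on an aromatic carbon; the site is an aromatic carbon of the five-membered aromatic ring with one oxygen, next to the ring oxygen. No step between measured compounds covers this kind of change, so the expectation rests on compound 2 alone, with no reason drawn from the data for a large move either way. The expected step is a 1.5-fold lower number from compound 2 to compound 3 (0.18 log units; within the scatter), small, most likely toward a lower number, and not clearly beyond the scatter. For compound 3 in this assay the estimate is 18000 nM, with a range from 6000 nM to 50000 nM.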

Compound 3, concentration for 50% growth inhibition: 9000 nM
For compound 3 the middle estimate is 2.0-fold (0.30 log units) above the measured one, and the stated range covers the measured number.
By their numbers in this assay, from the lowest: compound 3; then compounds 1 and 2 (each within the scatter of the next).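

The carbon of the five-membered aromatic ring next to the ring oxygen is sensitive to substitution: in this assay, furan-2-yl to 5-chlorofuran-2-yl gives a 3.0-fold lower number from compound 2 to compound 3 (0.48 log units; beyond the scatter), a modest step. Among the compounds shown here, the earlier compounds differed in more than one place and their numbers could not be ordered, so this is the first change in one place with a readable direction. Here a single chlorine atom, with no ring, no hydrogen-bond donor or acceptor and no net charge, moves the number toward stronger growth inhibition. No independent data bear on why this step occurs, so the observation stands without an explanation.

Open for the series is whether the shift is specific to chloro or would also appear with bromo, methyl, methoxy or an amine on the same carbon. Also open, on these data alone, is whether the step keeps its size and direction when the methoxy group of the shared core is replaced by another group, such as a carboxylic acid.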